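Methoxy for methyl on the fused core of compound 1

This account rests on a few compounds, and the source may have more. Where it says the series, first, only, none or still open, it means among the compounds named here.

Of the compounds shown here, three have been measured in a functional assay on the whole organism for inhibition, with Brassica napus as the target, with a stated time of 72 h, tested at 100 mg/L; a lower number here means less inhibition of growth, a higher number more inhibition of growth at the concentration tested. Compound 1 `COc1cc(C)nc2n/c(=N/C(=O)c3c(-c4ccc(Cl)cc4Cl)noc3C)sn12` gives 80.6%, the highest of the three. Compound 2 `COc1cc(Cl)nc(NC(=S)NC(=O)c2c(-c3ccc(Cl)cc3Cl)noc2C)n1` gives 61%, and compound 3 `Cc1cc(Cl)nc(NC(=S)NC(=O)c2c(-c3ccc(Cl)cc3Cl)noc2C)n1` gives 50.8%. The gap between compound 1 and compound 2 lies beyond the scatter. The gap between compound 1 and compound 3 also lies beyond the scatter. Compounds 2 and 3 differ in one place: methoxy in place of methyl on an aromatic carbon. The step of a number 10.2 percentage points higher from compound 3 to compound 2 (beyond the scatter) is modest but beyond the scatter. The difference between the core of compound 1 and the core of compound 3 is not broken down here.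

Compound 4 `COc1cc(OC)n2s/c(=N\C(=O)c3c(-c4ccc(Cl)cc4Cl)noc3C)nc2n1` is not yet measured. It differs from compound 1 in one place: methoxy in place of methyl on an aromatic carbon. This is the same kind of change as from compound 3 to compound 2, not the same change: in compound 4 the site is part of a fused or bridged system of two rings, meta to a fused ring, meta to a methoxy group and para to a fused ring, whereas in compound 2 the site is meta to a chloro group and meta to a large group. The expected step is a number 5.4 percentage points higher from compound 1 to compound 4 (within the scatter), a guess resting on the measured step of a number 10.2 percentage points higher from compound 3 to compound 2 (beyond the scatter), tempered by the fact that compound 1 already gives 80.6% and the read-out cannot exceed full inhibition. Compound 4 is expected to give 86% in this assay, with a plausible range from 70% to 98%.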

Compound 4, percent growth inhibition at one concentration: 85.6%
Compound 4: the middle estimate sits 0.4 percentage points above what was measured; the measured number falls inside the stated range.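

In this assay, methoxy in place of methyl on an aromatic carbon of the core of compound 1 gives a number 5 percentage points higher from compound 1 to compound 4 (within the scatter). Set beside the earlier case of this change, the two cores cannot be told apart in how they respond: the same change on two cores in this assay, a number 10.2 percentage points higher (beyond the scatter) from compound 3 to compound 2 and a number 5 percentage points higher (within the scatter) from compound 1 to compound 4, 5.2 percentage points apart, within the scatter of two such steps This shows that the two steps agree within the scatter, but it does not establish that methoxy raises growth inhibition on the core of compound 1, since that step alone cannot be separated from the scatter, and two pairs with differently placed sites are too few to make a rule for the series.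

The compounds shown leave open how other groups at this site would behave on the core of compound 1, for example an amine or a longer chain such as butoxy, since only methyl and methoxy can be compared there. They also leave open whether compound 1 and compound 4 would separate at lower concentrations, as each is represented by a single-concentration read-out in this assay.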